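From oxan-3-yl to 4-chlorophenyl on the shared core

The source may hold more compounds than are shown below. What is called first, only, known or untested is meant among the compounds shown, and "the series" means these compounds.

In an in vitro ADME assay on microsomes from liver (Homo sapiens) for metabolic stability (a higher number here means faster removal of the compound, a lower number slower removal), compound 1 `CC(C)Nc1nccc(-c2cn[nH]c2)n1` gives 0.021 mL/min/kg and carries hydrogen on the aromatic carbon in question. Compound 2 `CC(C)Nc1nccc(-c2c[nH]nc2C2CCOCC2)n1` gives 0.018 mL/min/kg with oxan-4-yl at that carbon, and compound 3 `CC(C)Nc1nccc(-c2c[nH]nc2C2CCCOC2)n1` gives 0.034 mL/min/kg with oxan-3-yl there. Compound 3 stands within the scatter of both others: the measured steps to it are a 1.6-fold higher number from compound 1 to compound 3 (0.21 log units; within the scatter) and a 1.9-fold higher number from compound 2 to compound 3 (0.28 log units; within the scatter) and neither goes beyond that scatter. The remaining step is a 1.2-fold lower number from compound 1 to compound 2 (0.07 log units; within the scatter) and it also stays within the scatter.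

Compound 4 `CC(C)Nc1nccc(-c2c[nH]nc2-c2ccc(Cl)cc2)n1` is the next case. The change is 4-chlorophenyl in place of oxan-3-yl on an aromatic carbon with 4-chlorophenyl in place of oxan-3-yl on an aromatic carbon. The measured steps bear on it only in part, as none of them brings an aromatic ring or chlorine to this carbon. The largest of them, between compound 2 and compound 3, is a 1.9-fold higher number from compound 2 to compound 3 (0.28 log units; within the scatter) and remains within the scatter. No step beyond the scatter is therefore expected, and the expected step is a 1.2-fold higher number from compound 3 to compound 4 (0.07 log units; within the scatter) with wide uncertainty around it. The estimated value for compound 4 is 0.04 mL/min/kg with an expected range from 0.015 mL/min/kg to 0.1 mL/min/kg as its spread.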

Compound 4, clearance: 0.106 mL/min/kg
Estimate against measurement, compound 4: 2.7-fold (0.42 log units) below; the measured number lies above the stated range.
By their numbers in this assay, from the lowest: compounds 2, 1 and 3 (each within the scatter of the next); then compound 4.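

Within the data shown here, at this aromatic carbon, next to the ring nitrogen, 4-chlorophenyl is the first group to give a change beyond the scatter in this assay: there is a 3.1-fold higher number from compound 3 to compound 4 (0.49 log units; beyond the scatter) and a 5.9-fold higher number from compound 2 to compound 4 (0.77 log units; beyond the scatter) and a 5.0-fold higher number from compound 1 to compound 4 (0.70 log units; beyond the scatter). The position is therefore not indifferent to what it carries: hydrogen, oxan-4-yl and oxan-3-yl cannot be told apart there, while a six-membered aromatic ring of carbon only, bearing chlorine, gives faster removal than all three. No measurement at hand gives a cause for this rise.

Open, on these data alone, is whether the step belongs to the aromatic ring or to the chlorine, since the two enter together in compound 4 and plain phenyl at this carbon would separate them. Also open, as far as these compounds go, is how this carbon responds to groups outside the six-membered rings, such as an amine or a carboxylic acid.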